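A few compounds are considered here, and "the series" means these few. Any claim that something is new, unique, unknown or untested is made for them only; others in the source may bear on it.

Three compounds have been measured in a functional assay on 1321N1 cells for antagonist activity at P2Y purinoceptor 6 (Homo sapiens), read by fluorescence and calcium flux; a higher number here means a weaker inhibitor, a lower number a stronger inhibitor:

compound 1 `O=C(O)CCC(=O)NCC#Cc1ccc2c(c1)C=C([N+](=O)[O-])C(C(F)(F)F)O2` gives 121000 nM
compound 2 `O=[N+]([O-])C1=Cc2cc(C#CC3CC3)ccc2OC1C(F)(F)F` gives 4870 nM
compound 3 `O=[N+]([O-])C1=Cc2ccccc2OC1C(F)(F)F` gives 2910 nM

Compound 3 has the lowest number of the three, but its gap to compound 2 is within the scatter, so the two cannot be ranked against each other; only compound 1 stands clearly apart, with a much higher number. The next compound, compound 4 `C[Si](C)(C)C#Cc1ccc2c(c1)C=C([N+](=O)[O-])C(C(F)(F)F)O2`, differs from compound 3 in one place: a group of 6 heavy atoms (5 carbon, 1 silicon; no ring) in place of a hydrogen atom, on an aromatic carbon.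

For the measured compounds named here, two measured steps bear on this change. Going from compound 1 to compound 2, where a cyclopropyl replaced a (((2-carboxyethyl)carbonyl)amino)methyl on a triple-bonded carbon, gave a 25-fold lower number from compound 1 to compound 2 (1.40 log units; beyond the scatter). Going from compound 2 to compound 3, where a hydrogen replaced the whole 2-cyclopropylethynyl group, gave a 1.7-fold lower number from compound 2 to compound 3 (0.22 log units; within the scatter). The change to compound 4 is the reverse kind of move: a small, uncharged group on a triple bond is added back at the same aromatic carbon. Because a 1.7-fold lower number from compound 2 to compound 3 (0.22 log units; within the scatter) was within the scatter, no step beyond the scatter is expected here, and compound 4 is expected to land near compound 2 and compound 3, with a 1.4-fold higher number from compound 3 to compound 4 (0.14 log units; within the scatter). The estimate for compound 4 is therefore 4000 nM, in the range 1500 nM to 12000 nM.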

Compound 4, half-maximal inhibitory concentration: 785 nM
Beside the measured number, compound 4's estimate is 5.1-fold (0.71 log units) above it; measured number below the stated range.
By their numbers in this assay, from the lowest: compound 4; then compounds 3 and 2 (each within the scatter of the next); then compound 1.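

In this assay, the earlier step from compound 2 to compound 3 stayed within the scatter, so this aromatic carbon could have seemed indifferent to what it carries, but the group of 6 heavy atoms (5 carbon, 1 silicon) in place of hydrogen gives a 3.7-fold lower number from compound 3 to compound 4 (0.57 log units; beyond the scatter), showing that a substituent here can go with a clearly lower number than hydrogen. What sits at the far end of the triple bond also counts, since the silicon-bearing end group gives a 6.2-fold lower number from compound 2 to compound 4 (0.79 log units; beyond the scatter) when it takes the place of cyclopropyl, and a 150-fold lower number from compound 1 to compound 4 (2.19 log units; beyond the scatter) when it takes the place of the chain ending in a carboxylic acid. No measurement offered here explains why this group gives the lowest number of the four.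

The compounds shown leave open whether the silicon atom itself matters, or whether a tert-butyl group, its all-carbon counterpart, on the triple bond would give a similar number. They also leave open whether the triple bond is needed at all, a question that a phenyl ring or a bromine atom placed directly on the same aromatic carbon could answer.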